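A few compounds are considered here, and "the series" means these few. Any claim that something is new, unique, unknown or untested is made for them only; others in the source may bear on it.

Measured so far:
compound 1, `Nc1nn2c(O)cc(-c3ccccc3F)nc2c1[N+](=O)[O-]` — > 50 ug/mL
compound 2, `COc1ccc(NNCc2cc(O)n3nc(N)c([N+](=O)[O-])c3n2)cc1` — 5.1 ug/mL

In a functional assay on K562 cells (Homo sapiens) for inhibition (on this read-out lower numbers stand for stronger inhibition of growth and higher numbers for weaker inhibition of growth), compound 1 sits at the limit of > 50 ug/mL in this assay, at which 1 of the 2 values shown sits, a limit of the assay and not a number. Compound 2 gives 5.1 ug/mL in this assay, the only number shown in the pair. Compound 3, `Nc1nn2c(O)cc(CNNCCO)nc2c1[N+](=O)[O-]`, is not yet measured. It differs from compound 2 by 2-hydroxyethyl in place of 4-methoxyphenyl on an amine nitrogen. For the measured compounds named here, no step between measured compounds that differ in one place exists here, so the size of the change cannot be read off a prior pair. The aromatic ring of compound 2 is removed and a short chain enters; a loss of potency beyond the scatter is expected, though its size is uncertain. Compound 3 is estimated at 20 ug/mL, with a range from 5 ug/mL to 50 ug/mL, the expected step being a 3.9-fold higher number from compound 2 to compound 3 (0.59 log units; beyond the scatter).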

Compound 3, concentration for 50% growth inhibition: > 50 ug/mL
Compound 3: no number, only a limit; the forecaster's own chance of this, stated with the estimate: 35%; at least 2.5-fold (0.39 log units) between middle value and limit.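

For the compounds shown here, on the amine nitrogen whose other neighbour is an amine nitrogen, 2-hydroxyethyl in place of 4-methoxyphenyl gives an at least 9.8-fold higher number from compound 2 to compound 3 (0.99 log units; beyond the scatter) in this assay; this is the first readable step at this position, and it is beyond the scatter. Compound 3 carries a limit and not a number, so the step sets only a lower bound on the size of the change. The step between compound 1 and compound 3 cannot be read, and the series now gathers at one end of the read-out: the limit of > 50 ug/mL in this assay, at which 2 of the 3 values shown sit.

The change removes a six-membered aromatic ring and also shortens the group from 8 heavy atoms to 3, and the compounds shown do not separate these two changes. From the compounds shown here alone, whether phenyl, benzyl or a longer chain ending in a hydroxyl on the same nitrogen would keep the value of compound 2 stays open.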